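This account rests on a few compounds, and the source may have more. Where it says the series, first, only, none or still open, it means among the compounds named here.

Measured so far in a functional assay on HT-29 cells (Homo sapiens) for antiproliferative activity, read by sulforhodamine B assay, with a stated time of 72 h; a higher number here means a weaker inhibitor, a lower number a stronger inhibitor:
compound 1, `CCCCCCCCc1ccc(CCC(CO)(CO)NC(C)=O)c2ccccc12`: 36500 nM
compound 2, `CCCCCCCCc1ccc(CCC(CO)(CO)NC(=O)CCCCC)c2ccccc12`: 20300 nM
compound 3, `CCCCCCCCCC(=O)NC(CO)(CO)CCc1ccc(CCCCCCCC)c2ccccc12`: > 80000 nM

Compound 3 stands at the upper end of the series. For the measured compounds named here, its value of > 80000 nM in this assay is a limit, not a number, and it is the one value in the set that sits at the limit of > 80000 nM in this assay, at which 1 of the 3 values shown sits. Compound 1 gives 36500 nM and compound 2 gives 20300 nM; a 1.8-fold lower number from compound 1 to compound 2 (0.25 log units; within the scatter). Lengthening the acyl chain further weakens inhibition: an at least 2.1-fold higher number from compound 1 to compound 3 (0.34 log units; beyond the scatter), and an at least 3.9-fold higher number from compound 2 to compound 3 (0.59 log units; beyond the scatter).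

Compound 4, `CCCCCCCCc1ccc(CCC(CO)(CO)NC(=O)c2ccccc2)c2ccccc12`, has not been measured. Its change from compound 3 is phenyl in place of nonyl on a carbonyl carbon. This shortens the acyl group to something closer in size to the hexanoyl of compound 2 than to the decanoyl of compound 3, and the two steps into compound 3 both ran towards weaker inhibition as the chain grew, so the reverse direction, a lower number, is expected. Whether the aromatic ring behaves like a chain of similar size cannot be read from these three compounds.

Compound 4 is therefore estimated at 30000 nM, with a range of 12000 nM to 80000 nM, which means an expected at least 2.6-fold lower number from compound 3 to compound 4 (0.42 log units; beyond the scatter).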

Compound 4, half-maximal inhibitory concentration: 23000 nM
Beside the measured number, compound 4's estimate is 1.3-fold (0.12 log units) above it, within the range that was stated.
By their numbers in this assay, from the lowest: compounds 2, 4 and 1 (each within the scatter of the next). At a limit, above all of these: compound 3.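

In this assay the carbonyl carbon takes an aromatic ring as readily as a short chain: phenyl in place of pentyl gives a 1.1-fold higher number from compound 2 to compound 4 (0.05 log units; within the scatter) and phenyl in place of methyl gives a 1.6-fold lower number from compound 1 to compound 4 (0.20 log units; within the scatter) so compound 1, compound 2 and compound 4 sit together in this assay. Phenyl in place of nonyl gives an at least 3.4-fold lower number from compound 3 to compound 4 (0.54 log units; beyond the scatter) and this shows that the weak end of the series is tied to the nonyl group of compound 3 and not to every larger acyl group on this amide. The value of compound 3 is a limit and not a number: the limit of > 80000 nM in this assay, at which 1 of the 4 values shown sits.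

Open, from the compounds shown here alone, is whether a heptyl chain on the same carbonyl carbon reads with pentyl or with nonyl, and whether a benzoyl group carrying an amine or a carboxylic acid stays level with the plain phenyl of compound 4. The shared core is the same in all four compounds, so nothing here tells how a carboxylic acid or an amine in place of the amide would read.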